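A few compounds are considered here, and "the series" means these few. Any claim that something is new, unique, unknown or untested is made for them only; others in the source may bear on it.

Working notes on the series. For the measured compounds named here, compound 2 `CC1=C(SC(C)C(C)O)C(=O)c2ccccc2C1=O` is the reference point: in a functional assay on SW480 cells (Homo sapiens) for inhibition (on this read-out higher numbers stand for weaker inhibition and lower numbers for stronger inhibition), compound 2 gives 5530 nM, the only full number among the values so far. Compound 1 `CC1=C(SCCCCCCO)C(=O)c2ccccc2C1=O` differs only on the sulfur chain, and in this assay compound 1 stops at a limit, > 10000 nM. Going by the values given here, the single measured step, an at least 1.8-fold lower number from compound 1 to compound 2 (0.25 log units; that floor lies within the scatter), sits at the limit of > 10000 nM in this assay, at which 1 of the 2 values shown sits. Compound 3 `CC1=C(SCC(C)O)C(=O)c2ccccc2C1=O` is the untested analogue, with hydrogen in place of methyl on a saturated chain carbon bound to a saturated chain carbon and a sulfur. That change is smaller than the measured step, so no shift beyond the scatter is expected in this assay; the expected step is a 1.0-fold lower number from compound 2 to compound 3 (0.00 log units; within the scatter). Compound 3 is estimated at 5500 nM, between 2500 nM and 12000 nM.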

Compound 3, half-maximal inhibitory concentration: 5190 nM
Compound 3: middle estimate off by 1.1-fold (0.03 log units), on the high side; the measured number falls inside the stated range.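

Hydrogen in place of methyl on a saturated chain carbon bound to a saturated chain carbon and a sulfur gives, in this assay, a 1.1-fold lower number from compound 2 to compound 3 (0.03 log units; within the scatter). This methyl therefore makes no readable difference in this assay, which the earlier pair could not show. The other new step, an at least 1.9-fold lower number from compound 1 to compound 3 (0.28 log units; that floor lies within the scatter), gives only a floor: the limit of > 10000 nM in this assay, at which 1 of the 3 values shown sits.

Still open, from the compounds shown here alone, is whether a phenyl group on this carbon, or an amine in place of the hydroxy group, would move the number beyond the scatter.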